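Swapping the ring on a sulfonamide nitrogen

The source may hold more compounds than are shown below. What is called first, only, known or untested is meant among the compounds shown, and "the series" means these compounds.

Compound 1, `Cc1ccc(C(/C=C/c2ccc(F)cc2)=N\Nc2nncc3ccccc23)cc1`: 5.6 nM
Compound 2, `O=C1CS/C(=N/Nc2nncc3ccccc23)N1c1ccccc1`: 77 nM
Compound 3, `Cc1cc(NS(=O)(=O)c2ccc(Nc3nncc4ccccc34)cc2)no1`: 46 nM

These three compounds share a common core and were measured in a functional assay on MCF7 cells (Homo sapiens) for antiproliferative activity, read by sulforhodamine B assay, with a stated time of 72 h; on this read-out lower numbers stand for stronger inhibition and higher numbers for weaker inhibition. Among the three numbers, compound 3 stands second highest. Its nearest neighbour is compound 2, whose number lies within the scatter of compound 3, so the two cannot be placed in any order. Compound 1 gives a lower number than compound 3, and that gap lies beyond the scatter.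

Compound 4, `O=S(=O)(Nc1ccccn1)c1ccc(Nc2nncc3ccccc23)cc1`, differs from compound 3 in one place: pyridin-2-yl in place of 5-methyl-1,2-oxazol-3-yl on a sulfonamide nitrogen. A five-membered aromatic ring with 2 hetero atoms gives way to a six-membered aromatic ring with 1 hetero atom, on a sulfonamide nitrogen whose other neighbour is the sulfonyl sulfur. Among the measured compounds shown here, no measured pair in this set isolates a change of this kind, so the data give no direct guide to its size.

In this assay the step is expected to be small, in no clear direction, and not beyond the scatter: a 1.2-fold lower number from compound 3 to compound 4 (0.06 log units; within the scatter). Compound 4 is accordingly estimated at 40 nM, with a likely range from 12 nM to 130 nM.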

Compound 4, half-maximal inhibitory concentration: 53 nM
Estimate against measurement, compound 4: 1.3-fold (0.12 log units) below; the range from low to high includes it.
By their numbers in this assay, from the lowest: compound 1; then compounds 3, 4 and 2 (each within the scatter of the next).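

Among the compounds shown here, this pair is the first in the set to isolate a single change, here on a sulfonamide nitrogen whose other neighbour is the sulfonyl sulfur. In this assay the exchange of 5-methyl-1,2-oxazol-3-yl for pyridin-2-yl (a 1.2-fold higher number from compound 3 to compound 4 (0.06 log units; within the scatter)) leaves no difference that can be read, so at this position these two aromatic rings, one five-membered and one six-membered, cannot be told apart. Nothing available explains why the two rings give such similar numbers.

As far as these compounds go, whether this holds for a very different group on the same nitrogen, such as a plain methyl or a simple hydrogen, stays open. A single pair also cannot show how rings carrying an amine or a carboxylic acid would behave there.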